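The source may hold more compounds than are shown below. What is called first, only, known or untested is meant among the compounds shown, and "the series" means these compounds.

Working notes on the series. Compound 1 `S=C(Nc1ccccc1)OCCc1ccccn1` is the reference point. In an ADME assay on MT4 cells (Homo sapiens) for cytotoxicity, read by MTT assay (on this read-out higher numbers stand for lower toxicity in this test and lower numbers for higher toxicity in this test), compound 1 gives only a limit of the assay, > 100000 nM, not a number. Compound 2 `Cc1ccccc1NC(=S)OCCc1ccccn1` carries a methyl in place of hydrogen on an aromatic carbon; in this assay compound 2 likewise sits at a limit, > 100000 nM. Compound 3 `Cc1cccc(NC(=S)OCCc2ccccn2)c1`, with a methyl at another aromatic carbon, also gives a limit in this assay, > 100000 nM. The two measured steps, a step that the two limits leave unreadable from compound 1 to compound 2 and a step that the two limits leave unreadable from compound 1 to compound 3, therefore cannot be sized, because the limit of > 100000 nM in this assay, at which 3 of the 3 values shown sit, holds every value shown. Compound 4 `Cc1ccc(NC(=S)OCCc2ccccn2)cc1` differs from compound 1 by methyl in place of hydrogen on an aromatic carbon. Both measured methyl additions bear on this change, and neither moved the read-out off its limit, so for the step that the limit leaves unreadable from compound 1 to compound 4 no shift beyond the scatter is expected, in either direction. For compound 4 the expected result in this assay is 150000 nM, with an estimated range from 80000 nM to 400000 nM, most likely again reported only as a limit.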

Compound 4, half-maximal cytotoxic concentration: 75000 nM
Beside the measured number, compound 4's estimate is 2.0-fold (0.30 log units) above it; measured number outside the range, below it.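

In this assay the methyl on an aromatic carbon, para to a large group, is the only one of the methyl changes shown that yields a number rather than a limit: compound 4 gives 75000 nM. Read as a step, this is an at least 1.3-fold lower number from compound 1 to compound 4 (0.12 log units; that floor lies within the scatter), so a real shift at this position is possible but not established. The true size of the step stays unknown, and the steps to the other two methyl compounds cannot be read at all, because the values at the limit hold them open: the limit of > 100000 nM in this assay, at which 3 of the 4 values shown sit.

As far as these compounds go, whether a larger group at this same place, such as an ethyl group, a methoxy group or an amine, would take the read-out clearly beyond the scatter remains open. From the compounds shown here alone, it is also open whether a longer chain in place of the methyl would give a number different from that of compound 4.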